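The source may report more compounds than this note shows. Statements on the series, on what has been measured and on what is new or still open speak of the compounds shown alone.

Measured so far:
- compound 1, `Cc1cc(O)cc(-c2nn(CC#N)cc2-c2ccnc(-c3ccc(Oc4ccccc4)cc3)c2)c1`: 80%
- compound 2, `COc1cc(C)cc(-c2nn(CC#N)cc2-c2ccnc(-c3ccc(N(C)C)cc3)c2)c1`: 91%

Of the compounds shown here, two have been tested in a functional assay on UACC-257 cells (Homo sapiens) for cytotoxicity, read by sulforhodamine B assay, with a stated time of 48 h, tested at 0.01 uM; a lower number here means a stronger effect, a higher number a weaker effect of the compound at the concentration tested. Compound 1, `Cc1cc(O)cc(-c2nn(CC#N)cc2-c2ccnc(-c3ccc(Oc4ccccc4)cc3)c2)c1`, gives 80%. Compound 2, `COc1cc(C)cc(-c2nn(CC#N)cc2-c2ccnc(-c3ccc(N(C)C)cc3)c2)c1`, gives 91%, the higher of the two numbers, and the gap to compound 1 lies beyond the scatter of this assay. The two differ in more than one place, so no single step can be read from them.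

The next compound is compound 3, `Cc1cc(O)cc(-c2nn(CC#N)cc2-c2ccnc(-c3ccc(N(C)C)cc3)c2)c1`. Relative to compound 2 the change is hydrogen in place of methyl on an oxygen on an aromatic ring. It removes one heavy atom and leaves the rest of compound 2 untouched. For the measured compounds named here, no measured pair isolates this change; compound 1 also carries the hydroxy group, but with a different aryl group attached, so its number cannot be taken as a guide on its own.

For compound 3 the expectation is a step from compound 2 to compound 3 of a number 4 percentage points lower from compound 2 to compound 3 (within the scatter) in this assay, that is no clear move beyond the scatter, perhaps a slight drop in the number. Compound 3 is estimated at 87%, within a range from 74% to 100%.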

Compound 3, a percentage reported as activity, at one concentration (the size of the read-out at that concentration, not a potency): 81%
For compound 3 the middle estimate is 6 percentage points above the measured one; low and high end bracket the measured number.
By their numbers in this assay, from the lowest: compounds 1, 3 and 2 (each within the scatter of the next, the first and the last beyond it).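

In this assay, methoxy to hydroxy on the 3-methoxy-5-methylphenyl group gives a number 10 percentage points lower from compound 2 to compound 3 (within the scatter), so at the single concentration tested this read-out does not separate the free hydroxy group from its methyl ether. For the compounds shown here, with the 3-hydroxy-5-methylphenyl group held constant, dimethylamino in place of phenoxy on an aromatic carbon gives a number 1 percentage points higher from compound 1 to compound 3 (within the scatter), the first single-place reading at that site, and it does not separate these two groups either. No evidence on hand explains either step.

Still open, as far as these compounds go, is whether an ethoxy group, an amino group or a fluorine on the aromatic ring in place of the hydroxy group would move the number beyond the scatter. At the other site, it remains to be seen whether a morpholine ring or a carboxylic acid in place of dimethylamino or phenoxy would separate from these two groups in this assay.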